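Methylsulfonyl for trifluoromethyl on a shared core

A few compounds are considered here, and "the series" means these few. Any claim that something is new, unique, unknown or untested is made for them only; others in the source may bear on it.

Compound 1 `O=C(Nc1ccc(Cl)c(-c2nnc3c(Cl)cccn23)c1)c1ccc(C(F)(F)F)cc1Cl`: in a functional assay on MDA-MB-231 cells (Homo sapiens) for antiproliferative activity, read by MTT assay, with stated times of 72 h and 4 h (a higher number here means a weaker inhibitor, a lower number a stronger inhibitor), compound 1 gives > 100000 nM, a limit of the assay.
Compound 2 `O=C(Nc1ccc(Cl)c(-c2nnc3c(Cl)cccn23)c1)c1ccc(C(F)(F)F)cc1F`: in this assay compound 2 gives > 100000 nM, likewise a limit of the assay.

Among the compounds with values here, compound 1 therefore stands only at a limit, and the one further value shown is a limit as well. Within the data shown here, the single measured step, a step that the two limits leave unreadable from compound 1 to compound 2, cannot be read in size or direction, since both ends sit at the limit (the limit of > 100000 nM in this assay, at which 2 of the 2 values shown sit).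

Compound 3 `CS(=O)(=O)c1ccc(C(=O)Nc2ccc(Cl)c(-c3nnc4c(Cl)cccn34)c2)c(Cl)c1` differs from compound 1 by methylsulfonyl in place of trifluoromethyl on an aromatic carbon. Among the measured compounds shown here, no measured step speaks to this change, and because the limit of > 100000 nM in this assay, at which 2 of the 2 values shown sit, is all that the two measured compounds show, no step beyond the scatter can be expected in either direction. Compound 3 is thus expected to fall at 100000 nM, within 30000 nM to 300000 nM, most probably again reported only as a limit. The expected step is a number no higher from compound 1 to compound 3 (the limit leaves the size open).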

Compound 3, half-maximal inhibitory concentration: 37200 nM
Estimate against measurement, compound 3: 2.7-fold (0.43 log units) above; the measured number falls inside the stated range.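

In this assay, methylsulfonyl in place of trifluoromethyl on this aromatic carbon gives an at least 2.6-fold lower number from compound 1 to compound 3 (0.42 log units; beyond the scatter). Compound 3 thereby shows that a change at this position, para to a large group, can bring the number down from the limit, something the step from chloro to fluoro could not show, as that step cannot be read. The step has only a lower bound, and compound 3 is the one compound shown with a measured number: the limit of > 100000 nM in this assay, at which 2 of the 3 values shown sit.

On these data alone, how far the step truly reaches remains open, as does whether methylsulfonyl would give a comparable step with fluoro in place of the chloro group on the same ring. Also open, as far as these compounds go, is whether an amine or a carboxylic acid on this aromatic carbon would lower the number further.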